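A few compounds are considered here, and "the series" means these few. Any claim that something is new, unique, unknown or untested is made for them only; others in the source may bear on it.

Measured in a functional assay on HCT-116 cells (Homo sapiens) for cytotoxicity, read by MTT assay, with a stated time of 72 h; on this read-out lower numbers stand for stronger inhibition and higher numbers for weaker inhibition:
Compound 1 `NCCCNc1c(C(=O)NCc2ccc(F)cc2)nc(Br)c2cccnc12` gives 18000 nM
Compound 2 `Nc1ccc(Nc2c(C(=O)NCc3ccc(F)cc3)nc(Br)c3cccnc23)cc1` gives 7000 nM

Of these two compounds, compound 1 has the higher number and is therefore the weaker. Compound 3 `O=C(NCCCNc1c(C(=O)NCc2ccc(F)cc2)nc(Br)c2cccnc12)c1ccccc1` differs from compound 1 in one place: benzoyl in place of hydrogen on an amine nitrogen, so that amino becomes benzamido. The full count of that change is benzoyl in place of hydrogen on an amine nitrogen and it leaves the shared core untouched.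

Going by the values given here, only one measured step bears on this, and only loosely. The step of a 2.6-fold lower number from compound 1 to compound 2 (0.41 log units; beyond the scatter) is modest and came with 4-aminophenyl in place of 3-aminopropyl on a nitrogen on an aromatic ring. Among the compounds with values here, compound 2 still carries an amino group, whereas compound 3 carries benzamido, so no measured step shows what benzoyl does here. A modest fall in this assay is expected, though a rise cannot be ruled out. The estimated change is a 1.6-fold lower number from compound 1 to compound 3 (0.21 log units; within the scatter) and it remains uncertain. For compound 3 the expected value is 11000 nM with an estimated range from 3500 nM to 30000 nM on this read-out.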

Compound 3, half-maximal inhibitory concentration: > 10000 nM
Compound 3: a limit, no number (the forecaster's own chance of this, stated with the estimate: 10%); the middle value is on the limit's open side.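

In this assay compound 3 gives > 10000 nM, which is a limit and not a number. Going by these compounds alone, no step from compound 1 to compound 3 can therefore be read. The compounds shown leave open what benzoyl in place of hydrogen on the amine nitrogen does, including whether compound 3 is stronger or weaker than compound 1.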